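This account rests on a few compounds, and the source may have more. Where it says the series, first, only, none or still open, it means among the compounds named here.

Measured in a functional assay on CHO cells for agonist activity at Alpha-1A adrenergic receptor (Homo sapiens), read by FLIPR and calcium flux (a lower number here means a smaller maximal response, a higher number a larger maximal response), so far:
- compound 1, `CCCS(=O)(=O)Nc1cccc2c1CCC2c1ncc[nH]1`: 54%
- compound 2, `CS(=O)(=O)Nc1cccc2c1CCC2c1ncc[nH]1`: 87%
- compound 3, `c1cc(-c2nccs2)c2c(c1)C(c1ncc[nH]1)CC2`: 64%

Compound 3 stands second highest of the three numbers in this assay. Its nearest neighbour is compound 1, from which it is separated by a number 10 percentage points higher from compound 1 to compound 3 (within the scatter). The furthest is compound 2; that gap is a number 23 percentage points lower from compound 2 to compound 3 (beyond the scatter).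

Compound 4, `c1cc(-c2cn[nH]c2)c2c(c1)C(c1ncc[nH]1)CC2`, is not yet measured in this assay. It differs from compound 3 in one place: 1H-pyrazol-4-yl in place of 1,3-thiazol-2-yl on an aromatic carbon.

Which measured steps bear on this? Both steps that end at compound 3 put 1,3-thiazol-2-yl in place of a sulfonamide-type group on the same aromatic carbon: a number 10 percentage points higher from compound 1 to compound 3 (within the scatter), within the scatter, and a number 23 percentage points lower from compound 2 to compound 3 (beyond the scatter), modest. The remaining step, a number 33 percentage points higher from compound 1 to compound 2 (beyond the scatter), is large but concerns the chain on the sulfonyl group, not the aromatic substituent. Among the measured compounds shown here, no measured step swaps one five-membered aromatic ring for another, so the move from compound 3 to compound 4 has no direct precedent in this set. With both rings of the same size and hetero-atom count, the working expectation is a step in this assay that stays within the scatter, direction undetermined.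

Compound 4 is therefore estimated at 65% in this assay, with a range of 45% to 85%. The expected step is a number 1 percentage points higher from compound 3 to compound 4 (within the scatter).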

Compound 4, largest response reached (Emax), in percent of the reference or control that the assay uses: 84%
Estimate against measurement, compound 4: 19 percentage points below; the range from low to high includes it.
By their numbers in this assay, from the lowest: compounds 1 and 3 (each within the scatter of the next); then compounds 4 and 2 (each within the scatter of the next).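

Notes on the aromatic carbon of the shared core: in this assay this place distinguishes between two five-membered aromatic rings with the same heavy-atom count and hetero-atom count (1H-pyrazol-4-yl in place of 1,3-thiazol-2-yl: a number 20 percentage points higher from compound 3 to compound 4 (beyond the scatter)), so ring size and hetero-atom count alone do not set the response. Set against the sulfonamide-type groups, 1H-pyrazol-4-yl stands level with methanesulfonamido (a number 3 percentage points lower from compound 2 to compound 4 (within the scatter)) but apart from (propylsulfonyl)amino (a number 30 percentage points higher from compound 1 to compound 4 (beyond the scatter)), which shows that a sulfonamide-type group is not needed here for a response in the range of compound 2. Nothing measured on these compounds accounts for the gap between the two rings.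

From the compounds shown here alone, the two rings also differ in their counts, with 1 hydrogen-bond donor on 1H-pyrazol-4-yl and 0 on 1,3-thiazol-2-yl, and whether that difference tracks the response remains open; 1-methyl-1H-pyrazol-4-yl on the same aromatic carbon would test it. Going by these compounds, how a carboxylic acid or an amine at this place would behave in this assay also remains open.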